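The compounds below may be only part of what the source reports. "The series", "measured", "known", "first", "only" and "open" are said of these compounds alone.

Of the compounds shown here, three have been measured in an assay for displacement of a labelled ligand from corticotropin-releasing factor receptor 1 (Homo sapiens); on this read-out higher numbers stand for weaker inhibition and lower numbers for stronger inhibition. Compound 1, `CCCCN(CC)C(=O)c1sc(Nc2c(Cl)cc(Cl)cc2Cl)nc1C`, gives 2800 nM in this assay. Compound 2, `CCCN(Cc1sc(Nc2c(C)cc(Cl)cc2Cl)nc1C(F)(F)F)CC1CC1`, gives 16 nM, and compound 3, `CCCN(Cc1sc(Nc2c(C)cc(C)cc2Br)nc1C(F)(F)F)CC1CC1`, gives 21 nM. Among these three numbers compound 3 stands second highest: its nearest neighbour is compound 2, and its furthest is compound 1, which lies beyond the scatter from it. For the measured compounds named here, the only step measured between two compounds that differ in one place, a 1.3-fold higher number from compound 2 to compound 3 (0.12 log units; within the scatter), exchanged 2-bromo-4,6-dimethylphenyl for 2,4-dichloro-6-methylphenyl on a nitrogen on an aromatic ring and stayed within the scatter.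

Compound 4, `CCCN(Cc1sc(Nc2c(C)cc(C)cc2Cl)nc1C(F)(F)F)CC1CC1`, differs from compound 3 in one place: chloro in place of bromo on an aromatic carbon. The step from compound 2 to compound 3 bears on this change, since it too rearranged only the halogen and methyl groups on that aromatic ring of carbon only, and it left the number within the scatter. Compound 4 is therefore expected to stay close to compound 3, with an estimated step of a 1.2-fold lower number from compound 3 to compound 4 (0.07 log units; within the scatter) that would itself lie within the scatter. The estimate for compound 4 in this assay is 18 nM, expected to fall between 8 nM and 40 nM.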

Compound 4, inhibition constant: 23 nM
Beside the measured number, compound 4's estimate is 1.3-fold (0.11 log units) below it; the range from low to high includes it.
By their numbers in this assay, from the lowest: compounds 2, 3 and 4 (each within the scatter of the next); then compound 1.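

In this assay, chloro in place of bromo on this aromatic carbon, ortho to a large group, gives a step within the scatter (a 1.1-fold higher number from compound 3 to compound 4 (0.04 log units; within the scatter)), so at this place the read-out does not separate the two halogens. A second single change, methyl in place of chloro on an aromatic carbon, also stays within the scatter (a 1.4-fold higher number from compound 2 to compound 4 (0.16 log units; within the scatter)), so compound 2, compound 3 and compound 4 form a flat set: these three arrangements of halogen and methyl groups on the ring give numbers that cannot be told apart. Nothing available explains why these exchanges leave the number so little changed.

Going by these compounds, it remains open whether this tolerance extends to groups of another kind at this carbon, such as a methoxy group, a nitrile or a plain hydrogen, or whether one of them would move the number beyond the scatter. Compound 1 differs from the other three in more than one place, so the compounds shown do not tell which of those differences accounts for its distance from them.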